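Changing the Cap on a Nitrogen

This account rests on a few compounds, and the source may have more. Where it says the series, first, only, none or still open, it means among the compounds named here.

In a functional assay on K562/Adr cells (Homo sapiens) for inhibition, read by MTT assay, with a stated time of 48 h (a higher number here means a weaker inhibitor, a lower number a stronger inhibitor), compound 1 `Nc1ccc(-c2cn([C@@H]3CN[C@H](C(=O)Nc4ccc(Cl)c(C(F)(F)F)c4)C3)nn2)cn1` gives 25200 nM. Compound 2 `C=CC(=O)Nc1ccc(-c2cn([C@@H]3CN[C@H](C(=O)Nc4ccc(Cl)c(C(F)(F)F)c4)C3)nn2)cn1` gives 80400 nM, the higher of the two numbers, which makes it the weaker inhibitor so far. Compound 3 `CS(=O)(=O)Nc1ccc(-c2cn([C@@H]3CN[C@H](C(=O)Nc4ccc(Cl)c(C(F)(F)F)c4)C3)nn2)cn1` has not yet been measured. It carries methylsulfonyl in place of vinylcarbonyl on a nitrogen on an aromatic ring. Among the measured compounds shown here, only one measured step bears on this spot, and it is modest: a 3.2-fold higher number from compound 1 to compound 2 (0.50 log units; beyond the scatter), from vinylcarbonyl in place of hydrogen on that nitrogen. For the measured compounds named here, no measured compound shows what methylsulfonyl does here, so the size of that step serves as the only guide. A change no larger than it is expected in this assay, leaning towards a lower number. The expected step is a 1.6-fold lower number from compound 2 to compound 3 (0.21 log units; within the scatter). Compound 3 is therefore estimated at 50000 nM, within a range of 20000 nM to 130000 nM.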

Compound 3, half-maximal inhibitory concentration: 4720 nM
Estimate against measurement, compound 3: 11-fold (1.03 log units) above; measured number outside the range, below it.
By their numbers in this assay, from the lowest: compound 3; then compound 1; then compound 2.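

In this assay, among the compounds shown here, the cap on this nitrogen matters far more than the one earlier step suggested: methylsulfonyl in place of vinylcarbonyl gives a 17-fold lower number from compound 2 to compound 3 (1.23 log units; beyond the scatter) and is a large step. Capping the nitrogen need not raise the number, since methylsulfonyl in place of hydrogen gives a 5.3-fold lower number from compound 1 to compound 3 (0.73 log units; beyond the scatter) and so runs opposite to the rise seen with vinylcarbonyl; the outcome here depends on which cap is attached and not merely on whether one is present. Nothing measured here explains the gap between these two caps, even though each has the same number of heavy atoms.

Still open, as far as these compounds go, is whether a plain acetyl cap would behave more like vinylcarbonyl or methylsulfonyl. Also open, from the compounds shown here alone, is whether ethylsulfonyl, with its longer chain, would keep the lower number seen with methylsulfonyl.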